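The source may report more compounds than this note shows. Statements on the series, on what has been measured and on what is new or still open speak of the compounds shown alone.

Compounds measured so far:
- Compound 1 `COc1cc(-n2ncnc2-c2ccc(OC(F)(F)F)cc2)cc(OC)c1OC`: > 10000 nM
- Compound 2 `COc1ccccc1-c1ncnn1-c1cc(OC)c(OC)c(OC)c1`: > 10000 nM

Both compounds were tested in a functional assay on A549 cells (Homo sapiens) for antiproliferative activity, read by MTT assay, with a stated time of 72 h; a higher number here means a weaker inhibitor, a lower number a stronger inhibitor. In this assay, compound 2 gives > 10000 nM, which is a limit of the assay and not a number. Compound 1 gives > 10000 nM, which is also a limit. The whole record so far is the limit of > 10000 nM in this assay, at which 2 of the 2 values shown sit. Among the compounds with values here, compound 2 therefore cannot be ranked against compound 1, and no measured step shows how much a structural change can matter here.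

The next compound is compound 3 `COc1cc(-n2ncnc2-c2ccc(SC)cc2)cc(OC)c1OC`. Within the data shown here, it has 4-(methylsulfanyl)phenyl in place of 2-methoxyphenyl on an aromatic carbon, the only structural difference from compound 2: 4-(methylsulfanyl)phenyl in place of 2-methoxyphenyl on an aromatic carbon.

Compound 2 shows the limit > 10000 nM, so any number that can be read for compound 3 is expected to lie lower. Among the measured compounds shown here, with no measured step as a guide, the expected size is uncertain, and compound 3 may well remain at the limit too. The estimated change is an at least 3.3-fold lower number from compound 2 to compound 3 (0.52 log units; beyond the scatter). For compound 3, the estimated value is 3000 nM, with an expected range from 100 nM to 10000 nM.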

Compound 3, half-maximal inhibitory concentration: 800 nM
Compound 3: middle estimate off by 3.8-fold (0.57 log units), on the high side, within the range that was stated.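

In this assay, compound 3 gives the first readable number, which shows that the group on this aromatic carbon of the five-membered ring can decide whether a value appears at all. Replacing 2-methoxyphenyl with 4-(methylsulfanyl)phenyl gives an at least 12-fold lower number from compound 2 to compound 3 (1.09 log units; beyond the scatter), even though both groups have the same count of heavy atoms, hydrogen-bond donors and hydrogen-bond acceptors. Changing only trifluoromethoxy to methylsulfanyl on the phenyl ring gives an at least 12-fold lower number from compound 1 to compound 3 (1.09 log units; beyond the scatter), so one small group there is enough to separate a readable number from a limit of the assay, and both steps are minimum sizes because each starts from a limit and not a number: the limit of > 10000 nM in this assay, at which 2 of the 3 values shown sit.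

Compound 2 differs from compound 3 in both the group on the phenyl ring and where it sits, so that step cannot show which of the two matters. As far as these compounds go, it also remains open whether the sulfur atom itself is important, and whether a longer chain such as ethylsulfanyl or an amine such as dimethylamino in place of methylsulfanyl would give a lower or higher number than compound 3.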